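Moving a methyl group around the benzyl ring

The source may report more compounds than this note shows. Statements on the series, on what has been measured and on what is new or still open speak of the compounds shown alone.

Two compounds share a common core and differ only in one substituent on a benzyl ring. Compound 1 `COc1cccc(CN2CCC(NC(=O)c3cccc4ccccc34)CC2)c1` carries a methoxy group there, and in an assay on isolated protein for displacement of a labelled ligand from D(4) dopamine receptor (Homo sapiens) (a higher number here means a weaker inhibitor, a lower number a stronger inhibitor), compound 1 gives 168 nM. Compound 2 `Cc1cccc(CN2CCC(NC(=O)c3cccc4ccccc34)CC2)c1` carries a methyl group instead, and in this assay compound 2 gives 77 nM. The step of a 2.2-fold lower number from compound 1 to compound 2 (0.34 log units; beyond the scatter) is modest. Among the two measured compounds, compound 2 stands lowest.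

Compound 3 `Cc1ccc(CN2CCC(NC(=O)c3cccc4ccccc34)CC2)cc1` keeps the methyl group but places it differently: 4-methylphenyl in place of 3-methylphenyl on a saturated chain carbon bound to an amine nitrogen in a ring. Said one bond further out, a 3-methylbenzyl becomes a 4-methylbenzyl.

Within the data shown here, no measured step covers this kind of change. Among the measured compounds shown here, the only step known, from a methoxy to a methyl group, concerns a different group at the same place and says nothing about shifting the methyl around the ring. With nothing to lean on, the expectation for compound 3 is a number close to that of compound 2, with a step of a 1.3-fold higher number from compound 2 to compound 3 (0.11 log units; within the scatter) that may well fall within the scatter. Compound 3 is therefore estimated at 100 nM, with a range from 35 nM to 300 nM.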

Compound 3, inhibition constant: 69 nM
Estimate against measurement, compound 3: 1.4-fold (0.16 log units) above, and the stated range covers the measured number.
By their numbers in this assay, from the lowest: compounds 3 and 2 (each within the scatter of the next); then compound 1.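

Moving the methyl group from 3-methylbenzyl to 4-methylbenzyl gives a 1.1-fold lower number from compound 2 to compound 3 (0.05 log units; within the scatter), so in this assay these two placements cannot be told apart. Among these compounds, this is the first sign that, for a methyl group on this benzyl ring, the exact place on the ring matters little in this pair, although two compounds are too few to make that a rule. Both methyl compounds also stand clear of the methoxy compound: beside the earlier 2.2-fold lower number from compound 1 to compound 2 (0.34 log units; beyond the scatter) there is now a 2.4-fold lower number from compound 1 to compound 3 (0.39 log units; beyond the scatter), so the gap to compound 1 appears with either placement, and nothing at hand explains it or the likeness of the two methyl compounds.

Still open, as far as these compounds go, is whether the methoxy group of compound 1 would read the same after the same shift around the ring, or whether the insensitivity belongs to the methyl group alone. From the compounds shown here alone, it is equally open how a larger or very different group would behave at these places on the ring, such as an ethyl group, a chlorine atom, an amine or a carboxylic acid.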